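The source may report more compounds than this note shows. Statements on the series, on what has been measured and on what is new or still open speak of the compounds shown alone.

Measured in a functional assay on HeLa cells (Homo sapiens) for antiproliferative activity, read by MTT assay, with a stated time of 48 h; on this read-out lower numbers stand for stronger inhibition of growth and higher numbers for weaker inhibition of growth:
compound 1 `COC(=O)N1N=C(c2ccc(OC)cc2)CC1c1cc(OC)c(OC)c(OC)c1`: 2590 nM
compound 2 `CCCOC(=O)N1N=C(c2ccc(OC)cc2)CC1c1cc(OC)c(OC)c(OC)c1`: > 10000 nM
compound 3 `COc1ccc(C2=NN(C(=O)OCc3ccccc3)C(c3cc(OC)c(OC)c(OC)c3)C2)cc1`: > 10000 nM

Compound 1 is the only one of the three with a real number in this assay. For compound 2, > 10000 nM is a limit of the assay and not a number. For compound 3, > 10000 nM is likewise a limit.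

The compound still to be measured is compound 4 `COC(=O)N1N=C(c2ccc(OC)c(OC)c2)CC1c1cc(OC)c(OC)c(OC)c1`. Its difference from compound 1 is this: methoxy in place of hydrogen on an aromatic carbon. In words, 4-methoxyphenyl becomes 3,4-dimethoxyphenyl.

The measured steps are an at least 3.8-fold higher number from compound 1 to compound 2 (0.58 log units; beyond the scatter) and an at least 3.8-fold higher number from compound 1 to compound 3 (0.58 log units; beyond the scatter), while a step that the two limits leave unreadable from compound 2 to compound 3. All of them concern a saturated chain carbon bound to an oxygen next to a carbonyl group. None touches an aromatic carbon, so none gives a size or direction for this change. No step beyond the scatter is therefore expected, and the starting point remains compound 1 at 2590 nM. The expected result is a 1.2-fold higher number from compound 1 to compound 4 (0.06 log units; within the scatter). For compound 4 the estimate is 3000 nM, with an expected range from 600 nM to 10000 nM.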

Compound 4, concentration for 50% growth inhibition: 3390 nM
Compound 4: the middle estimate sits 1.1-fold (0.05 log units) below what was measured, and the stated range covers the measured number.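

In this assay, the change from 4-methoxyphenyl to 3,4-dimethoxyphenyl gives a 1.3-fold higher number from compound 1 to compound 4 (0.12 log units; within the scatter), so a methoxy group can enter on this aromatic carbon, ortho to a methoxy group, with no step beyond the scatter. This is the first change shown on an aromatic carbon, and the earlier steps concerned only the saturated chain carbon bound to an oxygen next to a carbonyl group. It is also the only step with a real number at both ends, since the other steps from compound 1 end in a limit of the assay: the limit of > 10000 nM in this assay, at which 2 of the 4 values shown sit.

Going by these compounds, whether a hydroxyl group, a fluorine atom or an amine on the same aromatic carbon would behave like methoxy remains open. The compounds shown also leave open whether the 3,4-dimethoxyphenyl group would give the same result alongside a longer chain than that of compound 1.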